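The compounds below may be only part of what the source reports. "The series", "measured", "known", "first", "only" and "open" are said of these compounds alone.

Compound 1, `CC(C)OC(=O)N1CCC(Oc2cccc3c2CCN3c2ccc(S(C)(=O)=O)cc2)CC1`, was tested in a functional assay on CHO-K1 cells for agonist activity at Glucose-dependent insulinotropic receptor (Homo sapiens), read by a luciferase reporter, with a stated time of 5 h (on this read-out lower numbers stand for an effect already at smaller amounts and higher numbers for an effect only at larger amounts of compound), where compound 1 gives 501 nM. Among the two compounds measured in this assay it stands at the highest number. Going by the values given here, the only comparison available is compound 2, `CC(C)OC(=O)N1CCC(Oc2ncnc3c2CCN3c2ccc(S(C)(=O)=O)cc2F)CC1`, which in this assay gives 50.1 nM, a markedly lower number than compound 1, well beyond the ordinary scatter of the measurement. Compound 2 differs from compound 1 in more than one place, so its values say nothing about any single change.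

Compound 3, `CC(C)(C)OC(=O)N1CCC(Oc2cccc3c2CCN3c2ccc(S(C)(=O)=O)cc2)CC1`, has not yet been measured. It differs from compound 1 in one place only: methyl in place of hydrogen on a saturated chain carbon bound to an oxygen next to a carbonyl group and two saturated chain carbons. Among the compounds with values here, no measured pair in this set isolates this change, so any expectation rests on compound 1 alone. The step of a 1.3-fold lower number from compound 1 to compound 3 (0.10 log units; within the scatter) is expected to be small, with no clear direction beyond the usual scatter. Compound 3 is therefore estimated to give about 400 nM in this assay, with a plausible range from 150 nM to 1200 nM.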

Compound 3, half-maximal effective concentration: 158 nM
For compound 3 the middle estimate is 2.5-fold (0.40 log units) above the measured one; measured number inside the range.
By their numbers in this assay, from the lowest: compound 2; then compound 3; then compound 1.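

In this assay the change from isopropoxycarbonyl to tert-butoxycarbonyl gives a 3.2-fold lower number from compound 1 to compound 3 (0.50 log units; beyond the scatter), so this position responds to a single added methyl on the saturated chain carbon bound to the oxygen, and the response lies beyond the scatter. Going by these compounds alone, the earlier compounds could not show this: compound 1 and compound 2 differ in more than one place, and this is the first step that isolates one change and shows its direction and size. Nothing measured here accounts for that direction or size.

As far as these compounds go, a single step sets no trend, so it remains open whether the number would keep falling with other groups at this place, such as a cyclobutyl, a 1-methylcyclopropyl or a 2,2,2-trifluoroethyl group, or whether tert-butyl already marks the end of the gain. From the compounds shown here alone, it also remains open whether going from isopropoxycarbonyl to tert-butoxycarbonyl would give a step of similar size on the core of compound 2, and whether an amide or a urea in place of the oxygen at this end of the molecule would keep the effect.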